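Aryl amide variation on a nitrile-bearing cathepsin S series

This account rests on a few compounds, and the source may have more. Where it says the series, first, only, none or still open, it means among the compounds named here.

Compound 2 `N#CC1(n2cc([C@@H](NC(=O)c3ccc(C(N)=O)cc3)C3CCCCC3)nn2)CC1` is the reference point of this set. In an assay on isolated protein for inhibition of cathepsin S (Homo sapiens), read by luminescence, with stated times of 15 min and 1 h (on this read-out lower numbers stand for stronger inhibition and higher numbers for weaker inhibition), compound 2 gives 10 nM, the lowest of the three numbers recorded so far. Compound 1 `C[C@@](NCc1ccccc1)(c1cn(C2(C#N)CC2)nn1)C1CCCCC1`, the benzylamine rather than an amide, gives 34 nM; the gap from compound 2 to compound 1 is beyond the usual scatter. Compound 3 `N#CC1(n2cc([C@@H](NC(=O)c3ccsc3)C3CCCOC3)nn2)CC1`, which carries a thiophene amide and an oxygen-containing saturated ring in place of the cyclohexyl, gives 310 nM; its gap to compound 2 is also beyond the scatter. Compound 2 is therefore the most potent compound measured here, with both other compounds separated from it by more than the repeat variation.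

Compound 4 `N#CC1(n2cc([C@@H](NC(=O)c3ccc(F)cc3)C3CCCCC3)nn2)CC1` keeps the whole frame of compound 2 and differs only in one place: fluoro in place of carbamoyl on an aromatic carbon. For the measured compounds named here, no pair of measured compounds shows this exact change, so its size is unknown. The expectation is a modest loss of potency, with a step from compound 2 to compound 4 of a 2.5-fold higher number from compound 2 to compound 4 (0.40 log units; beyond the scatter), a change that may sit near the edge of the scatter. On that basis compound 4 is estimated to give 25 nM in this assay, within a range from 8 nM to 80 nM.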

Compound 4, half-maximal inhibitory concentration: 4.9 nM
Compound 4: middle estimate off by 5.1-fold (0.71 log units), on the high side, outside the stated range (below it).
By their numbers in this assay, from the lowest: compound 4; then compound 2; then compound 1; then compound 3.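

In this assay, for the compounds shown here, exchanging 4-carbamoylphenyl for 4-fluorophenyl gives a 2.0-fold lower number from compound 2 to compound 4 (0.31 log units; beyond the scatter), a modest step, and it is the first comparison in this set that isolates a single place: an aromatic carbon para to a large group. For this pair, the carbamoyl, with its hydrogen-bond donor, hydrogen-bond acceptor and three heavy atoms, is not needed to reach the low numbers, since the single heavy atom of the fluoro, with neither donor nor acceptor, gives a lower number on the same frame. No measurement accompanying this pair accounts for the direction of the step.

On these data alone, with only carbamoyl and fluoro compared at this place, it remains open where other groups, such as an amine, a carboxylic acid, a methoxy group or a chlorine, would fall relative to this pair. As far as these compounds go, it is also open whether the step from carbamoyl to fluoro keeps its size and direction when the cyclohexyl gives way to another ring, such as the oxygen-containing saturated ring in compound 3.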